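The source may hold more compounds than are shown below. What is called first, only, known or untested is meant among the compounds shown, and "the series" means these compounds.

In a functional assay on B16 cells (Mus musculus) for cytotoxicity, read by MTT assay, with a stated time of 48 h (a higher number here means a weaker inhibitor, a lower number a stronger inhibitor), compound 1 (`CC(=O)OCCn1cc(CNC(=O)c2cn(Cc3ccccc3)nn2)nn1`) gives 28000 nM as a measured number. Compound 2 (`CC(=O)OCCn1cc(CNC(=O)c2cn(CC(=O)OCc3ccccc3)nn2)nn1`) gives > 100000 nM as a limit of the assay. Compound 3 (`CCOC(=O)Cn1cc(CNC(=O)c2cn(CCOC(C)=O)nn2)nn1`) gives > 100000 nM as a limit too, and so stands at the limit of > 100000 nM in this assay, at which 2 of the 3 values shown sit, with no number of its own. Compound 4 (`CC(=O)OCCn1cc(CNC(=O)c2cn(CCOC(C)=O)nn2)nn1`) differs from compound 3 by acetoxymethyl in place of ethoxycarbonyl on a saturated chain carbon bound to an aromatic nitrogen and the two have the same atoms, joined differently. Among the measured compounds shown here, the one measured step, an at least 3.5-fold higher number from compound 1 to compound 2 (0.55 log units; beyond the scatter) with benzyloxycarbonyl in place of phenyl, exchanges other groups and so bears only weakly on this change. No step beyond the scatter is therefore expected in this assay and the estimated step is a number no higher from compound 3 to compound 4 (the limit leaves the size open) at most. Compound 4 is estimated at 100000 nM (40000 nM to 250000 nM) and may well read as a limit again.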

Compound 4, half-maximal inhibitory concentration: > 100000 nM
Compound 4: only a limit was reported; the forecaster's own chance of this, stated with the estimate: 75%; the middle value sits exactly at the limit.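

In this assay acetoxymethyl in place of phenyl on a saturated chain carbon bound to an aromatic nitrogen gives an at least 3.5-fold higher number from compound 1 to compound 4 (0.55 log units; beyond the scatter) and so joins benzyloxycarbonyl as a second group here that ends at a limit. The steps from compound 2 and from compound 3 to compound 4 cannot be read, since both ends of each are limits. Only compound 1 keeps a measured number, and the others stand together: the limit of > 100000 nM in this assay, at which 3 of the 4 values shown sit.

From the compounds shown here alone, how far compound 2, compound 3 and compound 4 lie past that limit stays open. So does whether an amine, a carboxylic acid or a longer alkyl chain at this place would give a measured number.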